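Swapping a Dimethylthiophene for a Bare Thiophene

The source may hold more compounds than are shown below. What is called first, only, known or untested is meant among the compounds shown, and "the series" means these compounds.

Measured compounds:
- compound 1 `N=C(N)N/N=C/c1c(-c2ccsc2)nc2sccn12`: 30200 nM
- compound 2 `Cc1cn2c(/C=N/NC(=N)N)c(-c3cccs3)nc2s1`: 25100 nM
- compound 3 `Cc1cc(-c2nc3sc(C)cn3c2/C=N/NC(=N)N)c(C)s1`: 25100 nM

All three compounds share one core and differ only in the thiophene ring attached to it. In a functional assay on cells (Cancer cell lines, Homo sapiens) for inhibition (a higher number here means a weaker inhibitor of growth, a lower number a stronger inhibitor of growth), compound 1 gives 30200 nM, compound 2 gives 25100 nM and compound 3 gives 25100 nM. Compound 3 stands level with compound 2, and its gap to compound 1 is also within the scatter, so none of the three can be called stronger or weaker than the others.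

The next compound, compound 4 `Cc1cn2c(/C=N/NC(=N)N)c(-c3ccsc3)nc2s1`, is made from compound 3 by one change:
thiophen-3-yl in place of 2,5-dimethylthiophen-3-yl on an aromatic carbon

Among the compounds with values here, the one measured step that bears on this change, no change at the digits printed from compound 2 to compound 3 (within the scatter), replaced one thiophene ring with another and moved nothing beyond the scatter. Compound 1, which carries the same thiophen-3-yl ring as compound 4 on a core lacking a methyl group, also sits within the scatter of compound 3. The expectation is therefore a step of about a 1.1-fold higher number from compound 3 to compound 4 (0.03 log units; within the scatter), that is, no change beyond the scatter. Compound 4 is estimated at 27000 nM, with a likely range from 13000 nM to 56000 nM.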

Compound 4, concentration for total growth inhibition: 41700 nM
Estimate against measurement, compound 4: 1.5-fold (0.19 log units) below; the measured number falls inside the stated range.
By their numbers in this assay, from the lowest: compounds 2, 3, 1 and 4 (each within the scatter of the next).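

In this assay, taking both methyl groups off the thiophene ring gives a 1.7-fold higher number from compound 3 to compound 4 (0.22 log units; within the scatter), so at this position on the shared core, 2,5-dimethylthiophen-3-yl and thiophen-3-yl cannot be told apart. Exchanging thiophen-2-yl for thiophen-3-yl, with the rest of the molecule unchanged, gives a 1.7-fold higher number from compound 2 to compound 4 (0.22 log units; within the scatter), so the point at which the thiophene ring is attached makes no readable difference either. The first direct test of the methyl group on the core, methyl in place of hydrogen, gives a 1.4-fold higher number from compound 1 to compound 4 (0.14 log units; within the scatter), which also leaves that methyl with no readable effect. On these data alone, whether a phenyl ring in place of the thiophene, or an amine or a carboxylic acid on it, would move the number beyond the scatter remains open. Nothing available here offers an explanation for where these numbers fall.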